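Swapping Methoxy for Two Methyls on the Aryl Ring

A few compounds are considered here, and "the series" means these few. Any claim that something is new, unique, unknown or untested is made for them only; others in the source may bear on it.

Measured compounds:
compound 1 `CCC1=C(O)c2c(oc(-c3ccc(OC)cc3)cc2=O)C(CC)(CC)C1=O`: 0.68 uM
compound 2 `CCC1=C(O)c2c(oc(-c3cccc(OC(F)(F)F)c3)cc2=O)C(CC)(CC)C1=O`: 9.95 uM
compound 3 `CCC1=C(O)c2c(oc(-c3ccccc3C(F)(F)F)cc2=O)C(CC)(CC)C1=O`: 43.1 uM

Three compounds sharing one core and differing only in the aryl group attached next to the ring oxygen have been tested in a functional assay on KBVIN cells (Homo sapiens) for antiproliferative activity, read by sulforhodamine B assay, with a stated time of 3 days; on this read-out higher numbers stand for an effect only at larger amounts of compound and lower numbers for an effect already at smaller amounts. Compound 1, carrying a 4-methoxyphenyl group, gives 0.68 uM, the lowest number of the three. Compound 2, with a trifluoromethoxy-bearing phenyl ring, gives 9.95 uM, a gap to compound 1 that lies beyond the usual scatter. Compound 3, with a trifluoromethyl-bearing phenyl ring, gives 43.1 uM, the furthest from compound 1 and again beyond the scatter. Every departure from the methoxy group seen so far has thus raised the number.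

Compound 4 `CCC1=C(O)c2c(oc(-c3ccc(C)cc3C)cc2=O)C(CC)(CC)C1=O` has not yet been measured. It differs from compound 1 in a single place: 2,4-dimethylphenyl in place of 4-methoxyphenyl on an aromatic carbon. The methoxy oxygen is gone and two methyl groups take its place on the phenyl ring.

Going by the values given here, with no comparable step measured, an estimate must rest on compounds 2 and 3. Compound 2 gives 9.95 uM, well above compound 1. Compound 3 gives 43.1 uM, also well above compound 1. For compound 4 the expected step is a 7.4-fold higher number from compound 1 to compound 4 (0.87 log units; beyond the scatter), a rise beyond the scatter. Compound 4 is therefore estimated at 5 uM, within a range from 1.2 uM to 25 uM.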

Compound 4, concentration for half-maximal effect: 8.52 uM
Compound 4: the middle estimate sits 1.7-fold (0.23 log units) below what was measured, within the range that was stated.
By their numbers in this assay, from the lowest: compound 1; then compounds 4 and 2 (each within the scatter of the next); then compound 3.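

In this assay, replacing 4-methoxyphenyl with 2,4-dimethylphenyl gives a 13-fold higher number from compound 1 to compound 4 (1.10 log units; beyond the scatter), so at this position next to the ring oxygen the number also rises with a ring bearing only methyl groups, whereas the departures in compound 2 and compound 3 both carried fluorine. The step also holds the size of the group steady by heavy-atom count, and the aromatic ring is the same, while the group that leaves has an oxygen and a hydrogen-bond acceptor and the group that enters has neither. Nothing here provides a measured property that could explain the large step.

The change removes the methoxy group and adds two methyl groups at once, so these compounds cannot show how much of the step comes from losing the methoxy group and how much from the methyl groups themselves. A phenyl ring carrying a single methyl group, an ethoxy group in place of the methoxy group, or an amine on the ring would help separate these contributions.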